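The source may hold more compounds than are shown below. What is called first, only, known or untested is meant among the compounds shown, and "the series" means these compounds.

The measure here is a functional assay on RD cells (Homo sapiens) for inhibition, read by luminescence and ATP content, with a stated time of 72 h; a lower number here means that less compound is tolerated, a higher number that more compound is tolerated. Going by the values given here, compound 1 `CCCCc1ccc(-c2ccc3ncc(C(=O)OCC)cc3c2)cc1` is the first of the compounds examined. In this assay compound 1 gives > 7400 nM, which is a limit of the assay rather than a number. Compound 2 `CCOC(=O)c1cnc2ccc(-c3ccccc3)cc2c1` differs from compound 1 by hydrogen in place of butyl on an aromatic carbon. In this assay compound 2 gives > 7400 nM, again a limit and not a number. Compound 3 `Cc1nc(-c2cnc3ccc(-c4ccc(N)cc4)cc3c2)no1` carries a different pattern of groups on the shared core. In this assay compound 3 gives > 2500 nM, which is also a limit, not a number. Compound 3 thus stands at the limit of > 2500 nM in this assay, at which 1 of the 3 values shown sits, while the other two sit at the limit of > 7400 nM in this assay, at which 2 of the 3 values shown sit; none of the three gives an actual number.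

Compound 4 `CCCc1nc(-c2cnc3ccc(-c4ccc(N)cc4)cc3c2)no1` is the compound still to be measured. It differs from compound 3 by ethyl in place of hydrogen on a saturated chain carbon bound to an aromatic carbon. Among the compounds with values here, the only measured step of a related kind, a change in the length of a chain on an aromatic carbon, is a step that the two limits leave unreadable from compound 1 to compound 2, and it bears on the present change only loosely, since both of its ends are limits. A step of size a step that the limit leaves unreadable from compound 3 to compound 4 is therefore expected, meaning no change beyond the scatter. Compound 4 is estimated to give 5000 nM, within a range from 1500 nM to 20000 nM, most likely again reported as a limit.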

Compound 4, half-maximal cytotoxic concentration: > 800 nM
Compound 4 gave a limit, no number; the forecaster's own chance of this, stated with the estimate: 65%; the middle value lies beyond the limit too.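

In this assay compound 3 gives > 2500 nM, a limit and not a number. Going by these compounds alone, compound 4 gives > 800 nM, also a limit, so no step between compound 3 and compound 4 can be read. The compounds shown leave open whether going from 5-methyl-1,2,4-oxadiazol-3-yl to 5-propyl-1,2,4-oxadiazol-3-yl changes the tolerated concentration at all.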